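Compound 3 Carries a Larger Arm Than Compound 1

The source may hold more compounds than are shown below. What is called first, only, known or untested is meant among the compounds shown, and "the series" means these compounds.

Among the compounds with values here, compound 1 `CCCCc1cn(C[C@H](O)[C@H]2OC(=O)C(OCc3ccccc3)=C2OCc2ccccc2)nn1` is the only compound here with a numerical result: in a functional assay on HCT-116 cells (Homo sapiens) for antiproliferative activity, read by MTT assay, with a stated time of 72 h (on this read-out lower numbers stand for stronger inhibition and higher numbers for weaker inhibition), compound 1 gives 10400 nM. Compound 2 `CC(C)(C)OC(=O)N1CCN(C(=S)SCc2cn(C[C@H](O)[C@H]3OC(=O)C(OCc4ccccc4)=C3OCc3ccccc3)nn2)CC1` reaches only a limit of the assay, recorded as > 100000 nM in this assay. The picture so far is therefore one number and (the limit of > 100000 nM in this assay, at which 1 of the 2 values shown sits). Within the data shown here, no two measured compounds differ in a single place, so no measured step can be described, and the gap between compound 1 and compound 2 shows only that compound 2 sits beyond the reach of the assay while compound 1 does not.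

Compound 3 `O=C1O[C@H]([C@@H](O)Cn2cc(CNS(=O)(=O)c3ccc(Cl)cc3)nn2)C(OCc2ccccc2)=C1OCc1ccccc1` keeps the shared core of compound 1 and alters the group on the saturated chain carbon bound to an aromatic carbon: ((4-chlorophenyl)sulfonyl)amino in place of propyl on a saturated chain carbon bound to an aromatic carbon. The entering group is far larger than the propyl it replaces, and the only other large substituent at this position, in compound 2, coincided with a limit. In this assay the estimated step is a 2.9-fold higher number from compound 1 to compound 3 (0.46 log units; beyond the scatter), a loss of potency expected to lie somewhat beyond the scatter. Compound 3 is thus estimated at 30000 nM in this assay, with a range from 8000 nM to 100000 nM.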

Compound 3, half-maximal inhibitory concentration: 8380 nM
For compound 3 the middle estimate is 3.6-fold (0.55 log units) above the measured one; low and high end bracket the measured number.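

In this assay, putting ((4-chlorophenyl)sulfonyl)amino in place of propyl on a saturated chain carbon bound to an aromatic carbon gives a 1.2-fold lower number from compound 1 to compound 3 (0.09 log units; within the scatter). This place therefore accepts a far larger group, with a six-membered aromatic ring and added hydrogen-bond donor and acceptors, without a change that can be told from the scatter. Compound 3 also shows that a large group here does not by itself carry a compound beyond the reach of the assay, although compound 2 still stands as a limit and not as a number: the limit of > 100000 nM in this assay, at which 1 of the 3 values shown sits.

The single exchange brings in the aromatic ring, the chlorine and the hydrogen-bond donor and acceptors together, so the compounds shown do not tell whether any one of them matters on its own or whether their contributions merely leave the read-out level. A longer chain such as hexyl, a simple amine or a carboxylic acid on the same carbon would each test this place with only part of that change.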